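Compound 4 After a Carboxyphenyl-to-Bicycle Swap

This account rests on a few compounds, and the source may have more. Where it says the series, first, only, none or still open, it means among the compounds named here.

Measured so far in a functional assay on MCF7 cells (Homo sapiens) for inhibition, read by MTT assay, with a stated time of 72 h, tested at 10 uM; a lower number here means less inhibition, a higher number more inhibition at the concentration tested (going by the name of the read-out):
Compound 1, `CCOC(=O)C1=C(Nc2ccccc2)S/C(=C\c2ccc(O)c(O)c2)C1=O`, gives 38.1%.
Compound 2, `CCOC(=O)C1=C(Nc2ccccc2)S/C(=C\c2cccc(C(=O)O)c2)C1=O`, gives < 10%, which is a limit of the assay and not a number.
Compound 3, `CCOC(=O)C1=C(Nc2ccccc2)S/C(=C\c2cc(OC)ccc2OC)C1=O`, gives < 10%, which is likewise a limit and not a number.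

Compound 2 thus sits at the floor of what this assay reports, together with compound 3, as described by the limit of < 10% in this assay, at which 2 of the 3 values shown sit. Going by the values given here, the one step measured so far, a number at least 28.1 percentage points lower from compound 1 to compound 2 (beyond the scatter), shows that putting a 3-carboxyphenyl in place of a 3,4-dihydroxyphenyl loses most of the inhibition seen for compound 1.

Compound 4, `CCOC(=O)C1=C(Nc2ccccc2)S/C(=C\c2cc3ccncc3[nH]2)C1=O`, has not yet been measured. Its change from compound 2 is a group of 9 heavy atoms (7 carbon, 2 nitrogen; one five-membered aromatic ring with 1 hetero atom, one six-membered aromatic ring with 1 hetero atom) in place of a group of 9 heavy atoms (7 carbon, 2 oxygen; one six-membered aromatic ring of carbon only), on a double-bonded chain carbon bound to a double-bonded ring carbon. Among the compounds with values here, no measured step involves this bicyclic group, so the only guide is that compound 1, the one compound with a number rather than a limit, carries a hydrogen-bond donor on its ring, and the entering group also carries one donor. This gives a weak reason to expect some return of inhibition, but the step is expected to be small, a number at least 5 percentage points higher from compound 2 to compound 4 (that floor lies within the scatter), and may not lift compound 4 above the limit at all. Compound 4 is therefore expected to give 15%, somewhere between 5% and 35%.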

Compound 4, a percentage reported as inhibition, at one concentration (the size of the read-out at that concentration, not a potency): 18.2%
Beside the measured number, compound 4's estimate is 3.2 percentage points below it; the range from low to high includes it.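

Compound 4 shows that in this assay a group other than 3,4-dihydroxyphenyl can give a measured number at this place, on a double-bonded chain carbon bound to a double-bonded ring carbon, although the change from the catechol-free comparison with compound 1 is a number 19.9 percentage points lower from compound 1 to compound 4 (beyond the scatter). Replacing the 3-carboxyphenyl with the bicyclic group, which has the same hydrogen-bond donor and acceptor counts, gives a number at least 8.2 percentage points higher from compound 2 to compound 4 (that floor lies within the scatter), and this figure rests on a limit rather than a number for compound 2, so it does not establish a real gain. On these data alone, the true size of that step stays unknown, because compound 2 remains at the assay's floor: the limit of < 10% in this assay, at which 2 of the 4 values shown sit.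

The compounds shown leave open whether a phenyl ring carrying a single hydroxyl or an amine at this place would keep the inhibition of compound 1 or fall toward that of compound 4. The rest of the core is the same in all four compounds, so they also do not show how an amide in place of its ester would alter these results.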